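Swapping the anilide ring: dichlorophenyl to dimethylphenyl

The compounds below may be only part of what the source reports. "The series", "measured", "known", "first", "only" and "open" are said of these compounds alone.

Measured compounds:
compound 1 `O=C(/C=C/C(=O)N1C/C(=C\c2ccccc2)C(=O)/C(=C/c2ccccc2)C1)Nc1ccc(Cl)c(Cl)c1` gives 7500 nM
compound 2 `Cc1ccc(NC(=O)/C=C/C(=O)N2C/C(=C\c3ccc([N+](=O)[O-])cc3)C(=O)/C(=C/c3ccc([N+](=O)[O-])cc3)C2)cc1` gives 4400 nM
compound 3 `O=C(/C=C/C(=O)N1C/C(=C\c2ccc([N+](=O)[O-])cc2)C(=O)/C(=C/c2ccc([N+](=O)[O-])cc2)C1)Nc1ccc(Cl)c(Cl)c1` gives 1700 nM

These three compounds were tested in a functional assay on L1210 cells (Mus musculus) for cytotoxicity; on this read-out lower numbers stand for stronger inhibition and higher numbers for weaker inhibition. Among the three, compound 1 has the highest number, and its gap to compound 2 lies within the scatter, while its gap to compound 3 is beyond it. The unmeasured compound 4 `Cc1cccc(C)c1NC(=O)/C=C/C(=O)N1C/C(=C\c2ccccc2)C(=O)/C(=C/c2ccccc2)C1` differs from compound 1 in one place: 2,6-dimethylphenyl in place of 3,4-dichlorophenyl on an amide-type nitrogen.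

Among the compounds with values here, only one measured step touches the ring on this amide-type nitrogen: a 2.6-fold lower number from compound 2 to compound 3 (0.41 log units; beyond the scatter). There, a methyl-bearing phenyl was replaced by the dichlorophenyl and the number fell. The change from compound 1 to compound 4 runs the other way, taking the dichlorophenyl out and putting a methyl-bearing phenyl in, so a modest rise in the number is expected, though the earlier step was seen on a different core and with a differently substituted methylphenyl, which weakens the transfer. Compound 4 is therefore estimated at 13000 nM, within 4500 nM to 38000 nM, meaning an expected step of a 1.7-fold higher number from compound 1 to compound 4 (0.24 log units; within the scatter).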

Compound 4, half-maximal inhibitory concentration: 22000 nM
Compound 4: middle estimate off by 1.7-fold (0.23 log units), on the low side, within the range that was stated.
By their numbers in this assay, from the lowest: compound 3; then compounds 2 and 1 (each within the scatter of the next); then compound 4.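

In this assay, the step of a 2.9-fold higher number from compound 1 to compound 4 (0.47 log units; beyond the scatter) shows that the ring on the amide-type nitrogen also moves the number beyond the scatter on the core of compound 1, and the 3,4-dichlorophenyl compound again holds the lower number, as in the step of a 2.6-fold lower number from compound 2 to compound 3 (0.41 log units; beyond the scatter). The two groups exchanged here have the same count of heavy atoms and each holds one aromatic ring of carbon only, so those counts do not distinguish them. No measurement shown accounts for the rise in the number.

From the compounds shown here alone, what stays open is whether the difference follows the chlorine atoms or the places the substituents occupy on the ring. A 3,4-dimethylphenyl or a 2,6-dichlorophenyl group on this nitrogen would separate those two possibilities.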